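Swapping pyridinyl for phenyl on the amide carbonyl

A few compounds are considered here, and "the series" means these few. Any claim that something is new, unique, unknown or untested is made for them only; others in the source may bear on it.

Going by the values given here, in a functional assay on spleen for antagonist activity at Alpha-1B adrenergic receptor (Rattus norvegicus) (on this read-out higher numbers stand for higher potency (the scale is a negative logarithm) and lower numbers for lower potency), compound 2 `COc1cc2nc(N3CCN(C(=O)c4ccccn4)[C@H]4CCCC[C@H]43)nc(N)c2cc1OC` gives 8.64, the higher of the two numbers measured so far. Compound 1 `COc1cc2nc(N3CCN(C(=O)c4ccc(C(C)=O)o4)[C@H]4CCCC[C@H]43)nc(N)c2cc1OC` gives 8.13 in this assay. Among the compounds with values here, the one measured step, a number 0.51 log units higher from compound 1 to compound 2 (beyond the scatter), exchanged one ring on the carbonyl carbon for another. Compound 3 `COc1cc2nc(N3CCN(C(=O)c4ccccc4)[C@H]4CCCC[C@H]43)nc(N)c2cc1OC` carries phenyl in place of pyridin-2-yl on a carbonyl carbon. That single step concerns a different ring, so it offers little direct guidance here, and a change not clearly beyond the scatter is expected. The estimated step is a number 0.14 log units lower from compound 2 to compound 3 (within the scatter). Compound 3 is expected to give 8.5, within a range from 8 to 9.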

Compound 3, negative logarithm of the antagonist equilibrium constant: 8.83
Estimate against measurement, compound 3: 0.33 log units below, and the stated range covers the measured number.
By their numbers in this assay, from the lowest: compound 1; then compounds 2 and 3 (each within the scatter of the next).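

In this assay, the ring nitrogen of pyridin-2-yl, the one hydrogen-bond acceptor in that ring, is not required at this carbonyl carbon: exchanging that ring for phenyl gives a number 0.19 log units higher from compound 2 to compound 3 (within the scatter), so the two rings cannot be told apart here. Phenyl in place of 5-acetylfuran-2-yl gives a number 0.70 log units higher from compound 1 to compound 3 (beyond the scatter), so a ring of carbon only also stands clear of that furan. Nothing available explains either step. On these data alone, whether a phenyl ring carrying an amine or a carboxylic acid would hold this level remains open, as does a non-aromatic ring such as cyclohexyl.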